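Hydrogen in place of ethyl on an aromatic nitrogen

The source may hold more compounds than are shown below. What is called first, only, known or untested is meant among the compounds shown, and "the series" means these compounds.

Compound 1 `COc1cccc(/C=C/C(=O)c2c(O)c3ccccc3[nH]c2=O)c1` gives 38500 nM
Compound 2 `CCn1c(=O)c(C(=O)/C=C/c2ccc(OC)c(OC)c2)c(O)c2ccccc21` gives > 50000 nM

Both results come from an ADME assay on THP-1 cells (Homo sapiens) for cytotoxicity, read by MTT assay, with a stated time of 72 h; a lower number here means a stronger inhibitor, a higher number a weaker inhibitor. Compound 2 stands at > 50000 nM, which is a limit of the assay and not a number. Its true value is therefore unknown, and any step starting from compound 2 is uncertain.

Compound 3 `COc1ccc(/C=C/C(=O)c2c(O)c3ccccc3[nH]c2=O)cc1OC` differs from compound 2 in one place: hydrogen in place of ethyl on an aromatic nitrogen. Going by the values given here, no measured pair shows what this change does in this assay. Among the compounds with values here, a modest step towards a lower number is expected, and the only numerical guide is compound 1 at 38500 nM. The estimated change is an at least 1.3-fold lower number from compound 2 to compound 3 (0.11 log units; that floor lies within the scatter). Compound 3 is expected at 38000 nM, with an estimated range from 15000 nM to 80000 nM.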

Compound 3, half-maximal inhibitory concentration: > 50000 nM
Compound 3 was reported as a limit; the forecaster's own chance of this, stated with the estimate: 40%; middle value at least 1.3-fold (0.11 log units) away from the limit.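

In this assay compound 3 gives > 50000 nM, which is a limit of the assay and not a number. The change from ethyl to hydrogen on the aromatic nitrogen therefore cannot be read, because compound 2 and compound 3 share the same limit: the limit of > 50000 nM in this assay, at which 2 of the 3 values shown sit.

Compound 3 does add a second comparison, methoxy in place of hydrogen on an aromatic carbon, which gives an at least 1.2-fold higher number from compound 1 to compound 3 (0.11 log units; that floor lies within the scatter), so this pair shows no firm change, although the true gap could be larger.

From the compounds shown here alone, what an ethyl on the aromatic nitrogen does to cytotoxicity remains open, as neither compound in that pair has a measured number. The compounds shown also leave open how a longer chain, or a chain ending in an amine, would behave on that nitrogen.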